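Working notes on the shared core: carbamoyl side chain shortened

The source may hold more compounds than are shown below. What is called first, only, known or untested is meant among the compounds shown, and "the series" means these compounds.

Compound 1 `NC(=O)[C@@H]1CCCN1c1cc(=O)oc2cc(OCc3ccccc3)ccc12` carries the 2-carbamoylpyrrolidin-1-yl group directly on the shared core, and in an assay (strain Wistar) for inhibition of Amine oxidase [flavin-containing] A (Rattus norvegicus) (on this read-out higher numbers stand for weaker inhibition and lower numbers for stronger inhibition), compound 1 gives 99800 nM. Compound 2 `NC(=O)[C@@H]1CCCN1Cc1cc(=O)oc2cc(OCc3ccccc3)ccc12` carries the same group as (2-carbamoylpyrrolidin-1-yl)methyl and in this assay compound 2 gives 35000 nM; the step is a 2.9-fold lower number from compound 1 to compound 2 (0.46 log units; beyond the scatter). Compound 3 `NC(=O)[C@@H]1CCCN1Cc1cc(=O)oc2cc(OCc3cccc(F)c3)ccc12` adds a fluoro and in this assay compound 3 reaches only a limit of the assay, > 100000 nM. The step is an at least 2.8-fold higher number from compound 2 to compound 3 (0.45 log units; beyond the scatter), compound 3 sitting at the limit of > 100000 nM in this assay, at which 1 of the 3 values shown sits. Compound 2 thus holds the lowest of the two numbers, compound 1 being the nearest.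

Compound 4 `CC(C(N)=O)c1cc(=O)oc2cc(OCc3ccccc3)ccc12` differs from compound 2 by 1-carbamoylethyl in place of (2-carbamoylpyrrolidin-1-yl)methyl on an aromatic carbon. Neither measured step bears directly on this: the first changes only the linkage of the same group and is modest, the second changes a different part of the molecule. Going by the values given here, no measured step tests loss of the five-membered ring. A modest to moderate weakening is expected, giving a 1.9-fold higher number from compound 2 to compound 4 (0.27 log units; within the scatter). Compound 4 is estimated at 65000 nM, with a range from 20000 nM to 200000 nM. A limit-only result for compound 4 is expected to remain possible.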

Compound 4, half-maximal inhibitory concentration: 6260 nM
Compound 4: the middle estimate sits 10-fold (1.02 log units) above what was measured; measured number below the stated range.
By their numbers in this assay, from the lowest: compound 4; then compound 2; then compound 1. At a limit, above all of these: compound 3.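

In this assay, the position opposite the ring oxygen does not depend on the five-membered ring: 1-carbamoylethyl in place of (2-carbamoylpyrrolidin-1-yl)methyl gives a 5.6-fold lower number from compound 2 to compound 4 (0.75 log units; beyond the scatter). Measured against the directly attached 2-carbamoylpyrrolidin-1-yl group, the same replacement gives a 16-fold lower number from compound 1 to compound 4 (1.20 log units; beyond the scatter), so the smaller open-chain group carrying the carbamoyl sits lowest among the numbers at this position. Nothing measured here on any property of these groups accounts for the step.

Still open, as far as these compounds go, is whether the lower number belongs to the carbamoyl group itself, which a carboxylic acid or a nitrile at that place would test, or to the branching methyl, which a plain carbamoylmethyl would test. A longer chain or an amine in place of the carbamoyl would show how far this position tolerates other groups.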